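Adding a Methoxy Group to a Chloro Amide Core

This account rests on a few compounds, and the source may have more. Where it says the series, first, only, none or still open, it means among the compounds named here.

Compound 1 `CN1CCC(NC(=O)c2ccc(Nc3ncc([N+](=O)[O-])c(NC4CCCC4)n3)cc2)CC1` gives 21700 nM in a functional assay on HeLa cells (Homo sapiens) for cytotoxicity, read by MTT assay, with a stated time of 48 h; on this read-out lower numbers stand for stronger inhibition and higher numbers for weaker inhibition.
Compound 2 `COc1cc(C(=O)NC2CCN(C)CC2)ccc1Nc1ncc(Br)c(NC2CCCC2)n1` gives 3500 nM in this assay.
Compound 3 `CN1CCC(NC(=O)c2ccc(Nc3ncc(Cl)c(NC4CCCC4)n3)cc2)CC1` gives 1500 nM in this assay.

Compound 3 stands lowest of the three numbers; compound 2 is its nearest neighbour and compound 1 the furthest. Among the compounds with values here, the single one-point change measured so far, a 14-fold lower number from compound 1 to compound 3 (1.16 log units; beyond the scatter), was a large step. Compound 4 `COc1cc(C(=O)NC2CCN(C)CC2)ccc1Nc1ncc(Cl)c(NC2CCCC2)n1` differs from compound 3 by methoxy in place of hydrogen on an aromatic carbon. Within the data shown here, no measured step shows a methoxy group added on its own, so that step bears only indirectly. Compound 2, which carries both a methoxy group and a bromine, gives a number moderately above that of compound 3, and nothing suggests a large shift in either direction. The step expected here is small: a 1.7-fold higher number from compound 3 to compound 4 (0.22 log units; within the scatter). Compound 4 is estimated at 2500 nM, within 900 nM to 7000 nM.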

Compound 4, half-maximal inhibitory concentration: 2700 nM
Compound 4: the middle estimate sits 1.1-fold (0.03 log units) below what was measured, within the range that was stated.
By their numbers in this assay, from the lowest: compounds 3, 4 and 2 (each within the scatter of the next, the first and the last beyond it); then compound 1.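

In this assay, methoxy in place of hydrogen, on the aromatic carbon meta to the (1-methylpiperidin-4-yl)carbamoyl group, gives a 1.8-fold higher number from compound 3 to compound 4 (0.26 log units; within the scatter) and so shows no clear effect of the group on its own at this position. With the methoxy group in place, chloro in place of bromo gives a 1.3-fold lower number from compound 2 to compound 4 (0.11 log units; within the scatter) and leaves the two halogens indistinguishable here. Nothing available explains either step. Open, on these data alone, is whether a hydroxyl group, an ethoxy group or an amine on this same carbon would also stay within the scatter of compound 3.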